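Methyl for Methoxy on the Amide Nitrogen

The source may hold more compounds than are shown below. What is called first, only, known or untested is meant among the compounds shown, and "the series" means these compounds.

Among the compounds with values here, in an ADME assay on the whole organism (Macaca fascicularis) for metabolic stability, at a dose of 1 mg/kg by the oral route (on this read-out lower numbers stand for a shorter-lived compound and higher numbers for a longer-lived compound), compound 2 `CONC(=O)c1ccc(C)cc1-c1ccc([C@@H](C)N(CC2CC2)c2nc(C(=O)NS(=O)(=O)C3CC3)c(C3CC3)s2)cc1` gives 2.9 h, one of only two numbers available, and its sole neighbour, compound 1 `Cc1ccc(-c2nc(=O)s[nH]2)c(-c2ccc([C@@H](C)N(CC3CC3)c3nc(C(=O)NS(=O)(=O)C4CC4)c(C4CC4)s3)cc2)c1`, gives 3.2 h; the step of a 1.1-fold lower number from compound 1 to compound 2 (0.04 log units; within the scatter) stays within the scatter. Compound 3 `CNC(=O)c1ccc(C)cc1-c1ccc([C@@H](C)N(CC2CC2)c2nc(C(=O)NS(=O)(=O)C3CC3)c(C3CC3)s2)cc1` differs from compound 2 by methyl in place of methoxy on an amide-type nitrogen. Within the data shown here, no measured step touches this part of the molecule; the one step known concerned a different group on an aromatic carbon and did not move the number. The writer therefore expects no step beyond the scatter in this assay: no change at the digits printed from compound 2 to compound 3 (within the scatter). His estimate for compound 3 is 2.9 h, within 1.6 h to 5.2 h.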

Compound 3, half-life: 3 h
The estimate for compound 3 lay 1.0-fold (0.01 log units) below the measured number, and the stated range covers the measured number.
By their numbers in this assay, from the lowest: compounds 2, 3 and 1 (each within the scatter of the next).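

In this assay, methyl takes the place of methoxy on the amide-type nitrogen with no step beyond the scatter (a 1.0-fold higher number from compound 2 to compound 3 (0.01 log units; within the scatter)). The methylcarbamoyl group also stands within the scatter of the ring-bearing group of compound 1 (a 1.1-fold lower number from compound 1 to compound 3 (0.03 log units; within the scatter)), so all three compounds remain indistinguishable on this read-out. No evidence is available that bears on this result.

Going by these compounds, it remains open whether an unsubstituted amide, an ethyl group on the same nitrogen or a carboxylic acid in place of the methylcarbamoyl group would stay within this range.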